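Swapping methoxy for bromo across two inactive cores

The compounds below may be only part of what the source reports. "The series", "measured", "known", "first", "only" and "open" are said of these compounds alone.

Compound 1 `COc1ccc(S(=O)(=O)c2nc3ccccc3nc2N2CCCC2)cc1` was tested in a functional assay on PC-3 cells (Homo sapiens) for cytotoxicity, read by MTT assay, with a stated time of 72 h; on this read-out lower numbers stand for stronger inhibition and higher numbers for weaker inhibition. In this assay compound 1 reaches only > 50000 nM, which is a limit of the assay and not a number. Compound 2 `O=S(=O)(c1ccc(Br)cc1)c1nc2ccccc2nc1N1CCCC1` differs from compound 1 by bromo in place of methoxy on an aromatic carbon. In this assay compound 2 likewise stops at the limit > 50000 nM. The step that the two limits leave unreadable from compound 1 to compound 2 cannot be sized, because both values sit at the limit of > 50000 nM in this assay, at which 3 of the 3 values shown sit. Compound 3 `COc1ccc(S(=O)(=O)c2nc3ccccc3nc2N2CCc3ccccc3C2)cc1` carries a different core, differing from compound 1 by 1,2,3,4-tetrahydroisoquinolin-2-yl in place of pyrrolidin-1-yl on an aromatic carbon. In this assay compound 3 again gives the limit > 50000 nM, so the step that the two limits leave unreadable from compound 1 to compound 3 is also unreadable. Compound 4 `O=S(=O)(c1ccc(Br)cc1)c1nc2ccccc2nc1N1CCc2ccccc2C1` is not yet measured; it differs from compound 3 by bromo in place of methoxy on an aromatic carbon, the same change as from compound 1 to compound 2, at the same place. Set beside that unreadable step, the expected step is a step that the limit leaves unreadable from compound 3 to compound 4, resting on compound 1, compound 2 and compound 3 all sitting at the limit of > 50000 nM in this assay, at which 3 of the 3 values shown sit. Compound 4 is therefore expected to give about 60000 nM, most likely again only a limit, within an expected range from 25000 nM to 150000 nM.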

Compound 4, half-maximal inhibitory concentration: > 50000 nM
Compound 4 was reported as a limit (the forecaster's own chance of this, stated with the estimate: 80%); the middle value lies beyond the limit too.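

No new step can be read from compound 3 or compound 2 to compound 4, because all four compounds give the same result, which is a limit and not a number: the limit of > 50000 nM in this assay, at which 4 of the 4 values shown sit.

The compounds shown leave open whether bromo in place of methoxy, or 1,2,3,4-tetrahydroisoquinolin-2-yl in place of pyrrolidin-1-yl, makes any difference in this assay.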